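Amino in place of methoxy at the cytotoxicity limit

The source may hold more compounds than are shown below. What is called first, only, known or untested is meant among the compounds shown, and "the series" means these compounds.

In an ADME assay on L929 cells (Mus musculus) for cytotoxicity, read by resazurin assay, with a stated time of 72 h (a lower number here means a stronger inhibitor, a higher number a weaker inhibitor), compound 1 `COc1cccc(C(=O)/C=C/c2ccc3c(c2)B(O)OC3)c1` gives only a limit, > 10 ug/mL. On these data alone, compound 2 `COc1ccc(C(=O)/C=C/c2ccc3c(c2)B(O)OC3)cc1OC` also gives only a limit, > 10 ug/mL, so its true position is unknown. The evidence so far is the limit of > 10 ug/mL in this assay, at which 2 of the 2 values shown sit. Among the compounds with values here, the only measured step is a step that the two limits leave unreadable from compound 1 to compound 2. Compound 3 `COc1cc(C(=O)/C=C/c2ccc3c(c2)B(O)OC3)ccc1N` has amino in place of methoxy on an aromatic carbon, ortho to a methoxy group and para to a large group: amino in place of methoxy on an aromatic carbon. Within the data shown here, no measured step gives a size or direction for this change. For compound 3 the expected step is a number no higher from compound 2 to compound 3 (the limit leaves the size open), none beyond the scatter. Compound 3 is estimated at 10 ug/mL, within a range from 4 ug/mL to 25 ug/mL.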

Compound 3, half-maximal inhibitory concentration: 1.45 ug/mL
Estimate against measurement, compound 3: 6.9-fold (0.84 log units) above; the whole stated range lies above it.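

In this assay, this position turns out to be sensitive to the group placed on it: amino in place of methoxy gives an at least 6.8-fold lower number from compound 2 to compound 3 (0.83 log units; beyond the scatter), and amino in place of hydrogen gives an at least 6.8-fold lower number from compound 1 to compound 3 (0.83 log units; beyond the scatter). Within the data shown here, compound 3 is the first compound here with a readable number, whereas the earlier step could not be read. Both sizes are only minimums because compound 1 and compound 2 each give a limit: the limit of > 10 ug/mL in this assay, at which 2 of the 3 values shown sit.

The compounds shown leave open whether a hydroxyl, methylamino or acetamido group on this carbon would give a similarly low number.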